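The source may hold more compounds than are shown below. What is called first, only, known or untested is meant among the compounds shown, and "the series" means these compounds.

In an in vitro ADME assay on microsomes from liver (Homo sapiens) for metabolic stability, tested at 1 uM (on this read-out higher numbers stand for a longer-lived compound and lower numbers for a shorter-lived compound), compound 1 `COc1cccc(CN2C(=O)C(C3=NS(=O)(=O)c4cc(NS(C)(=O)=O)ccc4N3)=C(O)[C@@H]3[C@@H]4CC[C@@H](C4)[C@@H]32)c1` gives > 1 h, a limit and not a number. Compound 2 `CS(=O)(=O)Nc1ccc2c(c1)S(=O)(=O)N=C(C1=C(O)[C@@H]3[C@@H]4CC[C@@H](C4)[C@@H]3N(Cc3ccc(F)c(F)c3F)C1=O)N2` gives > 1 h, also a limit. That places both compounds at the limit of > 1 h in this assay, at which 2 of the 2 values shown sit. Among the measured compounds shown here, the only measured step, a step that the two limits leave unreadable from compound 1 to compound 2, swapped one aromatic group for another and has no size to carry forward. Compound 3 `CC(C)CCN1C(=O)C(C2=NS(=O)(=O)c3cc(NS(C)(=O)=O)ccc3N2)=C(O)[C@@H]2[C@@H]3CC[C@@H](C3)[C@@H]21` differs from compound 2 by isobutyl in place of 2,3,4-trifluorophenyl on a saturated chain carbon bound to an amide-type nitrogen in a ring, with isobutyl in place of 2,3,4-trifluorophenyl, so the aromatic ring is lost. With no measured guide to size or direction, the expected step is none beyond the scatter, a step that the limit leaves unreadable from compound 2 to compound 3. Compound 3 is estimated at 1.5 h, within an expected range of 0.6 h to 5 h.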

Compound 3, half-life: 0.3 h
The estimate for compound 3 lay 5.0-fold (0.70 log units) above the measured number; the measured number lies below the stated range.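

This position matters for how long the compound lasts: in this assay, isobutyl in place of 2,3,4-trifluorophenyl gives an at least 3.3-fold lower number from compound 2 to compound 3 (0.52 log units; beyond the scatter), and isobutyl in place of 3-methoxyphenyl gives an at least 3.3-fold lower number from compound 1 to compound 3 (0.52 log units; beyond the scatter). The two aromatic groups could not be told apart, yet both comparisons with isobutyl can be read, and they point the same way. Both sizes are only minimums, since the compounds carrying an aromatic ring sit at a limit: the limit of > 1 h in this assay, at which 2 of the 3 values shown sit.

Going by these compounds, whether a saturated ring such as cyclohexyl at this place would match the aromatic groups or isobutyl stays open. So does the true half-life of compound 1 and compound 2.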